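The source may report more compounds than this note shows. Statements on the series, on what has been measured and on what is new or still open speak of the compounds shown alone.

Among the three measured compounds, compound 2 `Cc1ccc(Nc2nc(SCc3cn(CC(=O)NC(=O)Nc4ccccn4)nn3)nc(-c3ccc(C(C)C)cc3)c2C#N)cc1` stands at the lowest number in a functional assay on B16-F10 cells (Mus musculus) for inhibition, read by MTT assay, with a stated time of 72 h (on this read-out lower numbers stand for stronger inhibition and higher numbers for weaker inhibition), giving 3060 nM. Compound 1 `CC(C)c1ccc(-c2nc(SCc3cn(CC(=O)NC(=O)Nc4ccccn4)nn3)nc(Nc3ccccc3Cl)c2C#N)cc1` gives 6790 nM in this assay, and compound 3 `CC(C)c1ccc(-c2nc(SCc3cn(CC(=O)NC(=O)Nc4ccccn4)nn3)nc(Nc3ccccc3O)c2C#N)cc1` gives 16100 nM. All three measured steps fall on the anilino side of the shared core: a 2.2-fold lower number from compound 1 to compound 2 (0.35 log units; beyond the scatter), a 2.4-fold higher number from compound 1 to compound 3 (0.37 log units; beyond the scatter) and a 5.3-fold higher number from compound 2 to compound 3 (0.72 log units; beyond the scatter). Compound 4 `Cc1ccc(Nc2nc(SCc3cn(CC(=O)NC(=O)Nc4ccccn4)nn3)nc(-c3ccc(Br)cc3)c2C#N)cc1` departs from compound 2 at a different place: bromo in place of isopropyl on an aromatic carbon. Within the data shown here, no measured step touches this ring, so none bears directly on the change; the measured steps show only that single replacements on the shared core shifted the number by modest amounts, each beyond the scatter but none large. On that basis the step from compound 2 to compound 4 is expected to be of similar modest size, with a lean toward a higher number since compound 2 already holds the lowest value, as a 1.5-fold higher number from compound 2 to compound 4 (0.17 log units; within the scatter). For compound 4 the expected value in this assay is estimated at 4500 nM, with a range from 1500 nM to 14000 nM.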

Compound 4, half-maximal inhibitory concentration: 8160 nM
Compound 4: middle estimate off by 1.8-fold (0.26 log units), on the low side; the range from low to high includes it.
By their numbers in this assay, from the lowest: compound 2; then compounds 1, 4 and 3 (each within the scatter of the next, the first and the last beyond it).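

In this assay, among these compounds, the change from 4-isopropylphenyl to 4-bromophenyl gives a 2.7-fold higher number from compound 2 to compound 4 (0.43 log units; beyond the scatter), so this ring, which no earlier step touched, also moves the number beyond the scatter. In this single pair, with the rest of the structure unchanged, isopropyl gives stronger inhibition than bromo, though the step remains modest. Nothing among the data shown accounts for this step.

Only these two groups are compared at this place, both with the 4-methylphenyl kept on the nitrogen, so a trend across groups cannot be drawn, and a tert-butyl, methoxy or amino group on this carbon could help define one. From the compounds shown here alone, whether the step would hold with the 2-chlorophenyl or 2-hydroxyphenyl on that nitrogen also remains open.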